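The source may hold more compounds than are shown below. What is called first, only, known or untested is meant among the compounds shown, and "the series" means these compounds.

Measured so far:
compound 1 `CCC(c1ccc(O)c(O)c1)c1ccc(O)c(OC)c1`, 98%
compound 2 `CCC(c1ccc(O)c(OC)c1)c1ccccc1O`, 97%

Both numbers come from a functional assay for inhibition, with a stated time of 30 h, tested at 100 ug/mL; on this read-out lower numbers stand for less inhibition and higher numbers for more inhibition at the one concentration tested (going by the name of the read-out). Compound 2 stands lowest of the two, and its nearest neighbour is compound 1, a number only slightly higher and within the scatter, so no order between the two can be read. Compound 3 `CCC(c1ccc(O)c(OC)c1)c1cccc(O)c1O` differs from compound 2 in one place: hydroxy in place of hydrogen on an aromatic carbon. Within the data shown here, no step between measured compounds is available to set a size; with both measured values near the top of the read-out, no change beyond the scatter is expected, and the expected step is a number 1 percentage points lower from compound 2 to compound 3 (within the scatter). Compound 3 is estimated at 96%, within 86% to 100%.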

Compound 3, a percentage reported as inhibition, at one concentration (the size of the read-out at that concentration, not a potency): 97%
For compound 3 the middle estimate is 1 percentage points below the measured one, and the stated range covers the measured number.
By their numbers in this assay, from the lowest: compounds 2, 3 and 1 (each within the scatter of the next).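

Hydroxy in place of hydrogen on this aromatic carbon, ortho to a hydroxy group, gives no change at the digits printed from compound 2 to compound 3 (within the scatter) in this assay, the first one-place step in the series. The number therefore stays level with the added hydroxy, although with all values near the top of the read-out, a higher number would be hard to see. Nothing available bears on why the step reads this way.

Still open, as far as these compounds go, is how an amine or a carboxylic acid would read at this aromatic carbon. Also open, from the compounds shown here alone, is whether hydroxy here matters at all under conditions where the read-out is not near its top.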